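The source may hold more compounds than are shown below. What is called first, only, known or untested is meant among the compounds shown, and "the series" means these compounds.

Measured compounds in a physicochemical assay for lipophilicity; on this read-out higher numbers stand for higher lipophilicity and lower numbers for lower lipophilicity:
compound 1 `CC(C)C/C=C1/CC(CO)(COC(=O)CC(C(C)C)C(C)C)OC1=O` — compound 1 gives 4.1
compound 2 `CC(C)CC(=O)OCC1(CO)C/C(=C\CC(C(C)C)C(C)C)C(=O)O1` — compound 2 gives 4.1
compound 3 `CC(C)C(=CC(=O)O[C@@H](CO)COC(=O)CC(C(C)C)C(C)C)C(C)C` — compound 3 gives 5.7

In this assay compound 1 stands level with compound 2 at the digits shown, the two together lowest of the three; compound 3 is the furthest, a number beyond the scatter higher. Going by the values given here, no pair that differs in one place has been measured, so no step is on hand.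

Compound 4 `CC(C)C/C=C1\CC(CO)(COC(=O)CC(C(C)C)C(C)C)OC1=O` is still to be measured. Its difference from compound 1 is the two compounds have the same atoms and bonds; at least one stereo element is drawn with a configuration in one of them and without one in the other: 1 of 2 stereo elements differ; a double bond is drawn Z in compound 1 and E in compound 4. With no bond made or broken, nothing beyond the scatter is expected in this assay in either direction; the step of no change at the digits printed from compound 1 to compound 4 (within the scatter) is estimated as essentially nil. Compound 4 is expected at 4.1, range 3.7 to 4.5.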

Compound 4, partition coefficient: 4.1
The estimate for compound 4 equals the measured number at the digits printed; the range from low to high includes it.
By their numbers in this assay, from the lowest: compounds 1, 2 and 4 (each within the scatter of the next); then compound 3.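

In this assay, going by these compounds alone, the double-bond geometry is the first single change that can be read, and it gives no change at the digits printed from compound 1 to compound 4 (within the scatter). At this position, the read-out does not separate the two drawn geometries. One limit on reading this as a clean comparison of two defined geometries lies in the drawings: the fact that one of compounds 1 and 4 is drawn with a defined configuration and the other without, at the place where they differ

Going by these compounds, whether the geometry stays this silent with an amine or a carboxylic acid on the chain carried by the double bond remains open. On these data alone, a longer chain at the same position is equally open.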